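The source may hold more compounds than are shown below. What is called first, only, known or untested is meant among the compounds shown, and "the series" means these compounds.

Measured so far, in a functional assay on LNCaP cells (Homo sapiens) for cytotoxicity, read by resazurin assay; a higher number here means a weaker inhibitor, a lower number a stronger inhibitor:
- compound 1 `CC1=C[C@H](O)[C@@H](Br)C(C)(C)[C@@]12C=C[C@](C)(O)CC2`: >= 10000 nM
- compound 2 `CC1=CC(=O)CC(C)(C)[C@@]12C=C/C(=C/Br)CC2`: >= 10000 nM

Compound 2 gives no number, and its entry of >= 10000 nM is a limit of this assay. Compound 1 also gives only a limit, >= 10000 nM. Going by the values given here, the series so far amounts to the limit of >= 10000 nM in this assay, at which 2 of the 2 values shown sit.

Next in line is compound 3 `CC1=CC(=O)CC(C)(C)[C@@]12C=C/C(=C\Br)CC2`. Its change from compound 2 is the two compounds have the same atoms and bonds and differ only in configuration as drawn: 1 of 2 stereo elements differ; a double bond is drawn E in compound 2 and Z in compound 3. The atoms and bonds stay the same, and only the configuration as drawn differs.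

Among the compounds with values here, no measured step gives a size for such a change, so no shift beyond the usual scatter is expected, in either direction. The most likely outcome in this assay is another limit. The expected step of a number no higher from compound 2 to compound 3 (the limit leaves the size open) is therefore an estimate with little behind it. Compound 3 is estimated at 10000 nM, with an expected range from 4000 nM to 25000 nM.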

Compound 3, half-maximal inhibitory concentration: >= 10000 nM
Compound 3: a limit, no number; the forecaster's own chance of this, stated with the estimate: 80%; the middle value sits exactly at the limit.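

In this assay compound 3 gives >= 10000 nM, a limit and not a number. Compound 2 gives >= 10000 nM, also a limit, and no step can be read from compound 2 to compound 3. The compounds shown leave open whether the E and Z double bonds differ at all in this assay.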